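A few compounds are considered here, and "the series" means these few. Any claim that something is new, unique, unknown or untested is made for them only; others in the source may bear on it.

In a functional assay on L5178Y cells (Mus musculus) for inhibition, read by MTT assay, with a stated time of 24 h (a higher number here means a weaker inhibitor, a lower number a stronger inhibitor), compound 3 (`COc1ccc([C@@H]2C/C(=N\Nc3ccccc3)c3c(O)cc(OC)cc3O2)cc1`) gives >= 11300 nM, which is a limit and not a number. Compound 2 (`COc1ccc([C@@H]2C/C(=N\N)c3c(O)cc(OC)cc3O2)cc1`) gives >= 11300 nM, also a limit. Compound 1 (`COc1cc(O)c2c(c1)O[C@H](c1ccc(O)cc1)C/C2=N\NC(=O)c1ccco1`) gives >= 11300 nM, again a limit. For the measured compounds named here, compound 3 therefore has no measured number to stand on, and the series so far shows (the limit of >= 11300 nM in this assay, at which 3 of the 3 values shown sit).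

Compound 4 (`COc1ccc([C@@H]2C/C(=N\NC(=O)c3ccco3)c3c(O)cc(OC)cc3O2)cc1`) is reached from compound 3 by one change on the amine nitrogen: (furan-2-yl)carbonyl in place of phenyl on an amine nitrogen. In words, (furan-2-yl)carbonyl takes the place of phenyl on an amine nitrogen whose other neighbour is a double-bonded nitrogen.

Going by the values given here, the one measured step that touches this nitrogen is a step that the two limits leave unreadable from compound 2 to compound 3, so it offers no size to carry over. Compound 1 already carries the (furan-2-yl)carbonyl group, and its reading of >= 11300 nM is a limit as well. With nothing in this assay pointing in either direction, no step beyond the scatter is expected, and compound 4 will most likely report only a limit too. The estimated change is a step that the limit leaves unreadable from compound 3 to compound 4. For compound 4 the expected value is 15000 nM, with an estimated range from 6000 nM to 40000 nM.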

Compound 4, half-maximal inhibitory concentration: 2700 nM
Compound 4: the middle estimate sits 5.6-fold (0.74 log units) above what was measured, and the stated range ends above it.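

In this assay, the amine nitrogen whose other neighbour is a double-bonded nitrogen turns out to be a place where a change can move the reading: (furan-2-yl)carbonyl in place of phenyl gives an at least 4.1-fold lower number from compound 3 to compound 4 (0.62 log units; beyond the scatter) and the same group in place of hydrogen gives an at least 4.1-fold lower number from compound 2 to compound 4 (0.62 log units; beyond the scatter) in the series. The group does not do this alone, as compound 1 carries it too, and methyl in place of hydrogen on an oxygen on an aromatic ring gives an at least 4.1-fold lower number from compound 1 to compound 4 (0.62 log units; beyond the scatter) on top of that same group. Compound 4 is thus the only compound shown whose reading is a number and not a limit: the limit of >= 11300 nM in this assay, at which 3 of the 4 values shown sit.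

On these data alone, how far compound 1, compound 2 and compound 3 lie beyond their limits stays unknown, so the full size of these steps remains open. Also open, as far as these compounds go, is whether the carbonyl or the furan ring carries the step, which a benzoyl or an acetyl group on this nitrogen would bear on, and whether a longer chain in place of the methyl on the oxygen would keep it.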